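Swapping One Ring End: An Expectation for Compound 4

This account rests on a few compounds, and the source may have more. Where it says the series, first, only, none or still open, it means among the compounds named here.

Measured compounds in a functional assay on MCF7 cells (Homo sapiens) for cytotoxicity, read by sulforhodamine B assay, with a stated time of 48 h; on this read-out higher numbers stand for weaker inhibition and lower numbers for stronger inhibition:
compound 1, `Nc1ccc(C(=O)/C=C/c2ccc(O)c(F)c2)cc1-c1ccc(F)cc1`, gives 18300 nM
compound 2, `O=C(/C=C/c1cccc(Br)c1)c1cccc(-c2cccc(F)c2)c1`, gives 12700 nM
compound 3, `O=C(/C=C/c1cccc(-c2ccc(F)cc2)c1)c1ccc(O)cc1`, gives 10800 nM

Compound 1 carries the highest number of the three. Its nearest neighbour is compound 2, and its furthest is compound 3, yet both of those gaps fall within the usual scatter of repeated measurements, so none of the three can be called stronger or weaker than another on these numbers alone. Among the measured compounds shown here, no pair of measured compounds differs in only one place, so no single-change step has been measured.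

Compound 4, `COc1ccc(/C=C/C(=O)c2ccc(N)c(-c3ccc(F)cc3)c2)cc1`, has not yet been measured. It is built from compound 1 by one change: 4-methoxyphenyl in place of 3-fluoro-4-hydroxyphenyl on a double-bonded chain carbon bound to a double-bonded chain carbon. In this assay, the change removes a hydroxyl and a fluorine from the ring at that end and puts a methoxy in their place.

For the measured compounds named here, with no measured step to lean on, the expectation is a small shift, in either direction, most likely not beyond the scatter. Compound 4 is therefore estimated at 15000 nM, with a range from 5000 nM to 45000 nM. That estimate means a step of a 1.2-fold lower number from compound 1 to compound 4 (0.09 log units; within the scatter), expected to stay inside the scatter.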

Compound 4, half-maximal inhibitory concentration: 7580 nM
Compound 4: the middle estimate sits 2.0-fold (0.30 log units) above what was measured; the range from low to high includes it.
By their numbers in this assay, from the lowest: compounds 4, 3, 2 and 1 (each within the scatter of the next, the first and the last beyond it).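

In this assay, 4-methoxyphenyl in place of 3-fluoro-4-hydroxyphenyl on a double-bonded chain carbon bound to a double-bonded chain carbon gives a 2.4-fold lower number from compound 1 to compound 4 (0.38 log units; beyond the scatter), the first single-change step available in this set. It shows that this ring end is a place where one change can move the number past the ordinary spread of repeat measurements, and here the move is towards stronger inhibition. It also shows that, on the core of compound 1, the number does not get worse when the hydroxyl and the fluorine leave together and a methoxy enters, although nothing at hand explains the step.

Three things happen at once in this single step, and it does not reveal how much each contributes: the hydroxyl goes, the fluorine goes, and the methoxy arrives. Still open, going by these compounds, is how the number would respond to a ring keeping only the fluorine or only the methoxy, or to an amine or a carboxylic acid on that ring in place of the methoxy.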